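Tail amine series: chain-linked basic ends versus ring amine

This account rests on a few compounds, and the source may have more. Where it says the series, first, only, none or still open, it means among the compounds named here.

Within the data shown here, compound 3 `COc1ccc(Br)cc1CCc1c(F)cccc1C(=O)/N=C(\N)NCC1CCNCC1` gives 13 nM in an assay for binding affinity to Melanocortin receptor 4 (Homo sapiens) (on this read-out higher numbers stand for weaker inhibition and lower numbers for stronger inhibition), the highest number of the three measured so far; compound 1 `COc1ccc(Br)cc1CCc1c(F)cccc1C(=O)/N=C(\N)NCCCCN1CCCCC1` gives 0.58 nM and compound 2 `COc1ccc(Br)cc1CCc1c(F)cccc1C(=O)/N=C(\N)NCCCCN(C)Cc1ccccc1` gives 5.1 nM in this assay. Compound 4 `COc1ccc(Br)cc1CCc1c(F)cccc1C(=O)/N=C(\N)NCCCN1CCN(C)CC1` carries the change (2-(4-methylpiperazin-1-yl)ethyl in place of piperidin-4-yl on a saturated chain carbon bound to an amine nitrogen). The step bearing on it is a 22-fold higher number from compound 1 to compound 3 (1.35 log units; beyond the scatter), which shows that shortening a chain-linked tertiary amine to the ring amine weakens binding strongly; a 2.5-fold higher number from compound 2 to compound 3 (0.41 log units; beyond the scatter) points the same way with a smaller size, and an 8.8-fold higher number from compound 1 to compound 2 (0.94 log units; beyond the scatter) shows the end group itself matters. Compound 4 restores a chain-linked tertiary amine, so a move back toward lower numbers is expected, with a step of a 5.2-fold lower number from compound 3 to compound 4 (0.72 log units; beyond the scatter) estimated. Compound 4 is expected at 2.5 nM, in a range from 0.6 nM to 10 nM.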

Compound 4, inhibition constant: 64 nM
Compound 4: middle estimate off by 26-fold (1.41 log units), on the low side, outside the stated range (above it).
By their numbers in this assay, from the lowest: compound 1; then compound 2; then compound 3; then compound 4.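

A chain-linked tertiary amine does not by itself recover binding at this position: 3-(4-methylpiperazin-1-yl)propyl on the amine nitrogen gives a weaker result than the (piperidin-4-yl)methyl of the ring amine (a 4.9-fold higher number from compound 3 to compound 4 (0.69 log units; beyond the scatter)). The end group and chain together weigh heavily, as the distance from the longer-chain compounds shows (a 13-fold higher number from compound 2 to compound 4 (1.10 log units; beyond the scatter); a 110-fold higher number from compound 1 to compound 4 (2.04 log units; beyond the scatter)), though these two steps change both at once. Nothing at hand explains the loss.

Open, going by these compounds, is whether 3-(piperidin-1-yl)propyl would separate chain length from end group, and how a morpholine end on the longer chain would read.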